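The compounds below may be only part of what the source reports. "The series", "measured", "known", "first", "only" and "open" are said of these compounds alone.

The measured compounds and their numbers:

- Compound 1, `COc1ccc(Nc2cc(C)oc(=O)c2)cc1`: in a functional assay on DU-145 cells (Homo sapiens) for cytotoxicity, read by MTT assay, with a stated time of 72 h (on this read-out lower numbers stand for an effect already at smaller amounts and higher numbers for an effect only at larger amounts of compound), compound 1 reaches only the limit > 30 uM.
- Compound 2, `COc1ccc(Nc2cc(/C=C/c3ccccc3)oc(=O)c2)cc1`: in this assay compound 2 gives 0.11 uM.
- Compound 3, `COc1ccc(Nc2cc(-c3ccccc3)oc(=O)c2)cc1`: in this assay compound 3 gives 0.12 uM.

Among the measured compounds shown here, compound 3 holds the higher of the two numbers that were actually reached, but its only neighbour with a number, compound 2, lies so close that the step of a 1.1-fold higher number from compound 2 to compound 3 (0.04 log units; within the scatter) falls within the scatter, so the two count as equal. Compound 1 contributes only a limit (the limit of > 30 uM in this assay, at which 1 of the 3 values shown sits), not a number.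

Compound 4, `COc1ccc(Nc2cc(-c3ccco3)oc(=O)c2)cc1`, differs from compound 3 in one place: furan-2-yl in place of phenyl on an aromatic carbon. For the measured compounds named here, two measured steps bear on this. The step of an at least 250-fold lower number from compound 1 to compound 3 (2.39 log units; beyond the scatter) shows that placing an aromatic ring on this carbon instead of methyl brought a very large gain. The step of a 1.1-fold higher number from compound 2 to compound 3 (0.04 log units; within the scatter) shows that swapping one carbon-only aromatic group for another changed nothing beyond the scatter. Furan-2-yl is again an aromatic ring, so the expected step of a 1.7-fold higher number from compound 3 to compound 4 (0.22 log units; within the scatter) is small and not beyond the scatter, leaning if anything toward a slightly higher number. The estimate for compound 4 is therefore 0.2 uM, with a range from 0.06 uM to 0.7 uM.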

Compound 4, concentration for half-maximal effect: 1.95 uM
The estimate for compound 4 lay 9.8-fold (0.99 log units) below the measured number; the whole stated range lies below it.
By their numbers in this assay, from the lowest: compounds 2 and 3 (each within the scatter of the next); then compound 4. At a limit, above all of these: compound 1.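

Replacing phenyl with furan-2-yl, a five-membered aromatic ring with one oxygen, gives a 16-fold higher number from compound 3 to compound 4 (1.21 log units; beyond the scatter), and the same ring set against 2-phenylethenyl gives an 18-fold higher number from compound 2 to compound 4 (1.25 log units; beyond the scatter): at this carbon the kind of group matters, which the near-identical results for compound 2 and compound 3 could not reveal. Furan-2-yl still keeps a large part of the gain over methyl, with an at least 15-fold lower number from compound 1 to compound 4 (1.18 log units; beyond the scatter), so this position does not treat all aromatic rings alike, yet even the weaker ring here stands far from methyl. For compound 1 the value is a limit and not a number: the limit of > 30 uM in this assay, at which 1 of the 4 values shown sits.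

Going by these compounds, whether the loss follows the ring oxygen or the five-membered ring stays open, as the two change together in this single swap, and a thiophene ring or a pyridine ring at this carbon would help to separate them. Also open, on these data alone, is how this position would respond to a ring that is not aromatic, such as cyclohexyl, or to a phenyl ring carrying an amine or a carboxylic acid.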